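Swapping Chloro for Trifluoromethyl on a Benzimidazole Cytotoxicity Series

The compounds below may be only part of what the source reports. "The series", "measured", "known", "first", "only" and "open" are said of these compounds alone.

Measured compounds:
- compound 1 `C/C(=N\O)c1ccc2[nH]c(-c3ccc(Cl)cc3)nc2c1`: 37000 nM
- compound 2 `C/C(=N\O)c1ccc2[nH]c(-c3ccc(C(F)(F)F)cc3)nc2c1`: 55000 nM
- compound 3 `C/C(=N\NC(N)=S)c1ccc2c(c1)nc(-c1ccc(Cl)cc1)n2C1CCCCC1`: > 100000 nM

All three were tested in an ADME assay on MDBK cells (Bos taurus) for cytotoxicity, read by MTT assay, with a stated time of 96 h; on this read-out higher numbers stand for lower toxicity in this test and lower numbers for higher toxicity in this test. Compound 1 `C/C(=N\O)c1ccc2[nH]c(-c3ccc(Cl)cc3)nc2c1` gives 37000 nM. Compound 2 `C/C(=N\O)c1ccc2[nH]c(-c3ccc(C(F)(F)F)cc3)nc2c1` gives 55000 nM. The two differ by one change, (trifluoromethyl in place of chloro on an aromatic carbon), and the step of a 1.5-fold higher number from compound 1 to compound 2 (0.17 log units; within the scatter) lies within the scatter, so the two values cannot be told apart.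

Compound 3 `C/C(=N\NC(N)=S)c1ccc2c(c1)nc(-c1ccc(Cl)cc1)n2C1CCCCC1` carries a different core; how its core differs from that of compound 1 is not broken down here. In this assay, going by the values given here, compound 3 gives only a limit, > 100000 nM, and not a number; it is the one compound that sits at that limit (the limit of > 100000 nM in this assay, at which 1 of the 3 values shown sits).

Compound 4 `C/C(=N\NC(N)=S)c1ccc2c(c1)nc(-c1ccc(C(F)(F)F)cc1)n2C1CCCCC1` has not yet been measured. It differs from compound 3 by trifluoromethyl in place of chloro on an aromatic carbon, and the place of the change reads the same as between compound 1 and compound 2, so this is the same change. Because the measured step of a 1.5-fold higher number from compound 1 to compound 2 (0.17 log units; within the scatter) was within the scatter, the same change on compound 3 is expected to move the value little, so compound 4 is expected to remain at or beyond the limit, a step that the limit leaves unreadable from compound 3 to compound 4. Compound 4 is estimated at 130000 nM, with a likely range from 60000 nM to 300000 nM, and most probably this assay will again report only a limit.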

Compound 4, half-maximal cytotoxic concentration: > 100000 nM
Compound 4 gave a limit, no number; the forecaster's own chance of this, stated with the estimate: 80%; the middle value lies beyond the limit too.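

In this assay compound 4 gives > 100000 nM, which is a limit and not a number. Compound 3 also gives only a limit, so no step from compound 3 to compound 4 can be read: the limit of > 100000 nM in this assay, at which 2 of the 4 values shown sit.

From the compounds shown here alone, whether trifluoromethyl in place of chloro changes the value at all on the core of compound 3, and how far compound 3 and compound 4 lie past that limit, stays open.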